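A few compounds are considered here, and "the series" means these few. Any claim that something is new, unique, unknown or untested is made for them only; others in the source may bear on it.

Measured so far in an in vivo ADME assay on the whole organism (Cavia porcellus); on this read-out lower numbers stand for a shorter-lived compound and higher numbers for a longer-lived compound
compound 1 `CC(NC(=O)c1ccc(C(=N)N)cc1)C(C)(C)C(=O)N1CCC(CC(=O)O)CC1` gives 0.883 h
compound 2 `CC(C)C(NC(=O)c1ccc(C(=N)N)cc1)C(C)(C)C(=O)N1CCC(CC(=O)O)CC1` gives 0.8 h
compound 3 `CC(C)(C(=O)N1CCC(CC(=O)O)CC1)C(NC(=O)c1ccc(C(=N)N)cc1)c1ccc(O)cc1` gives 1.05 h

Compound 3 at 1.05 h sits within the scatter of the other two, with a 1.2-fold higher number from compound 1 to compound 3 (0.08 log units; within the scatter) and a 1.3-fold higher number from compound 2 to compound 3 (0.12 log units; within the scatter) as its steps. The change to compound 4 `CC(C)(C(=O)N1CCC(CC(=O)O)CC1)C(NC(=O)c1ccc(C(=N)N)cc1)c1cccc(Cl)c1` is 3-chlorophenyl in place of 4-hydroxyphenyl on a saturated chain carbon bound to an amide-type nitrogen and a saturated chain carbon with 3-chlorophenyl in place of 4-hydroxyphenyl on a saturated chain carbon bound to an amide-type nitrogen and a saturated chain carbon. Among the measured compounds shown here, no measured compound carries 3-chlorophenyl. The third step at that carbon is a 1.1-fold lower number from compound 1 to compound 2 (0.04 log units; within the scatter) and all three stay within the scatter, so no step beyond the scatter is expected in this assay and no direction is favoured. The expected size is a 1.1-fold lower number from compound 3 to compound 4 (0.02 log units; within the scatter) at this stage. The estimate for compound 4 is 1 h with 0.6 h to 1.7 h as the expected range.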

Compound 4, half-life: 2.5 h
The estimate for compound 4 lay 2.5-fold (0.40 log units) below the measured number, and the stated range ends below it.
By their numbers in this assay, from the lowest: compounds 2, 1 and 3 (each within the scatter of the next); then compound 4.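

In this assay this carbon now shows steps beyond the scatter, all with 3-chlorophenyl entering: against 4-hydroxyphenyl (a 2.4-fold higher number from compound 3 to compound 4 (0.38 log units; beyond the scatter)), against isopropyl (a 3.1-fold higher number from compound 2 to compound 4 (0.49 log units; beyond the scatter)) and against methyl (a 2.8-fold higher number from compound 1 to compound 4 (0.45 log units; beyond the scatter)). The position therefore responds to the group it carries, whereas methyl, isopropyl and 4-hydroxyphenyl stayed within the scatter of one another. Nothing at hand explains the longer half-life.

As far as these compounds go, whether the step belongs to the chlorine or to its place on the ring remains open. Unsubstituted phenyl, 4-chlorophenyl and 3-fluorophenyl at this carbon would separate these readings.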